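This account rests on a few compounds, and the source may have more. Where it says the series, first, only, none or still open, it means among the compounds named here.

In a functional assay on SH-SY5Y cells (Homo sapiens) for cytotoxicity, read by MTT assay, with stated times of 1 h and 24 h (on this read-out higher numbers stand for an effect only at larger amounts of compound and lower numbers for an effect already at smaller amounts), compound 3 (`COc1ccc2cc(C(=O)CCN3CCCCC3)c(=O)oc2c1`) gives > 100000 nM which is a limit of the assay and not a number. Compound 1 (`O=C(CCN1CCCCC1)c1cc2ccc(O)cc2oc1=O`) gives > 100000 nM which is likewise a limit. Compound 2 (`COc1ccc2cc(C(=O)CCN(C)C)c(=O)oc2c1`) gives > 100000 nM which is again a limit. Compound 3 therefore has no exact number to start from, and it shares the limit of > 100000 nM in this assay, at which 3 of the 3 values shown sit, so no order can be drawn among the three.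

The next compound, compound 4 (`COc1ccc2cc(C(=O)CCN3CCCC3)c(=O)oc2c1`), carries pyrrolidin-1-yl in place of piperidin-1-yl on a saturated chain carbon, two bonds along the chain from a carbonyl carbon. Going by the values given here, two measured steps bear on this change. The closer one is a step that the two limits leave unreadable from compound 2 to compound 3 and it alters the same place, with piperidin-1-yl in place of dimethylamino. The other is a step that the two limits leave unreadable from compound 1 to compound 3 and it lies elsewhere, with methyl in place of hydrogen on an oxygen on an aromatic ring. Given a step that the two limits leave unreadable from compound 2 to compound 3 at this very place, nothing points to a shift for compound 4. The step expected in this assay is none beyond the scatter in either direction, estimated as a number no higher from compound 3 to compound 4 (the limit leaves the size open) and quite possibly unreadable again. For compound 4 the estimated value is 100000 nM with an expected range from 50000 nM to 200000 nM and the assay may well report only a limit.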

Compound 4, half-maximal effective concentration: > 100000 nM
Compound 4 ended at the assay's limit; the forecaster's own chance of this, stated with the estimate: 85%; the middle value sits exactly at the limit.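

Compound 4 returns a limit and not a number, so its steps from compound 2 and compound 3 cannot be read, and all the compounds shown share one result: the limit of > 100000 nM in this assay, at which 4 of the 4 values shown sit.

None of these compounds gives an exact number in this assay, which leaves open whether any of these changes shifts the effect there at all.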